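This account rests on a few compounds, and the source may have more. Where it says the series, first, only, none or still open, it means among the compounds named here.

Measured so far in a functional assay on CHO cells for positive allosteric modulation of muscarinic acetylcholine receptor M5 (Homo sapiens), read by FLIPR and calcium flux, with a stated time of 1 h; on this read-out lower numbers stand for an effect already at smaller amounts and higher numbers for an effect only at larger amounts of compound:

- compound 1 `O=C1C(=O)N(Cc2cccc(Oc3ccccc3)c2)c2ccc(OC(F)(F)F)cc21`: compound 1 gives only a limit, > 30000 nM
- compound 2 `COc1cccc(Oc2ccc(CN3C(=O)C(=O)c4cc(OC(F)(F)F)ccc43)cc2)n1`: compound 2 gives 2200 nM
- compound 3 `O=C1C(=O)N(Cc2ccc(-c3ccncc3)nc2)c2ccc(OC(F)(F)F)cc21`: compound 3 gives 4400 nM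

Compound 2 holds the lowest of the two numbers; compound 3 sits within the scatter of it, so no order between the two can be read. Compound 1 is a limit only, as noted in the limit of > 30000 nM in this assay, at which 1 of the 3 values shown sits, and stands apart from both numbers.

For the measured compounds named here, no pair among the measured compounds differs in a single place, so no measured step is available. Compound 4 `O=C1C(=O)N(Cc2ccc(-c3ccccc3)cc2)c2ccc(OC(F)(F)F)cc21` is the unmeasured member. It differs from compound 2 by phenyl in place of (6-methoxypyridin-2-yl)oxy on an aromatic carbon, para to a large group. Compound 3 carries a different directly linked aromatic ring at a comparable position and gives 4400 nM, so a directly linked ring is tolerated in this assay. The step from compound 2 to compound 4 is expected to be small to moderate toward a higher number, a 2.3-fold higher number from compound 2 to compound 4 (0.36 log units; beyond the scatter), with a real chance of only a limit. Compound 4 is estimated at 5000 nM, range 1500 nM to 20000 nM.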

Compound 4, half-maximal effective concentration: 1600 nM
Beside the measured number, compound 4's estimate is 3.1-fold (0.49 log units) above it; the range from low to high includes it.
By their numbers in this assay, from the lowest: compounds 4, 2 and 3 (each within the scatter of the next, the first and the last beyond it). At a limit, above all of these: compound 1.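

For the compounds shown here, with phenyl in place of (6-methoxypyridin-2-yl)oxy on an aromatic carbon, para to a large group, a 1.4-fold lower number from compound 2 to compound 4 (0.14 log units; within the scatter) is the first single-place step in this assay, and no order can be read from it. At this position, the methoxy group, the ether oxygen and the ring nitrogen of the leaving group can therefore all be absent with no readable change in the number, at least when phenyl takes their place. No measurement given here bears on why the two groups read alike.

As far as these compounds go, whether an amine or a carboxylic acid on the same aromatic carbon would stay in this range remains open. Also open, from the compounds shown here alone, is what a plain hydrogen or a methoxy group there would give in place of a whole ring.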